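Swapping the pyrimidine on the sulfonamide nitrogen

The source may report more compounds than this note shows. Statements on the series, on what has been measured and on what is new or still open speak of the compounds shown alone.

Measured so far:
compound 1, `CC(=O)NS(=O)(=O)c1ccc(N/C(S)=N\c2ccnc3cc(C(F)(F)F)ccc23)cc1`: 58600 nM
compound 2, `Cc1cc(C)nc(NS(=O)(=O)c2ccc(N/C(S)=N\c3ccnc4cc(C(F)(F)F)ccc34)cc2)n1`: 52900 nM

In a functional assay on MDA-MB-231 cells (Homo sapiens) for antiproliferative activity, read by sulforhodamine B assay, with a stated time of 48 h (a higher number here means a weaker inhibitor, a lower number a stronger inhibitor), compound 1 gives 58600 nM and compound 2 gives 52900 nM. Compound 2 carries the lower of the two numbers, yet the step of a 1.1-fold lower number from compound 1 to compound 2 (0.04 log units; within the scatter) sits within the scatter, so the two are not separable. Compound 3, `COc1cc(NS(=O)(=O)c2ccc(N/C(S)=N\c3ccnc4cc(C(F)(F)F)ccc34)cc2)nc(OC)n1`, is not yet measured; it differs from compound 2 by 2,6-dimethoxypyrimidin-4-yl in place of 4,6-dimethylpyrimidin-2-yl on a sulfonamide nitrogen. Going by the values given here, the only measured step at this position, a 1.1-fold lower number from compound 1 to compound 2 (0.04 log units; within the scatter), stayed within the scatter, so no move beyond the scatter is expected here. For compound 3 the expected value is 55000 nM, with a range of 25000 nM to 120000 nM. The expected step is a 1.0-fold higher number from compound 2 to compound 3 (0.02 log units; within the scatter).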

Compound 3, half-maximal inhibitory concentration: 52100 nM
Compound 3: the middle estimate sits 1.1-fold (0.02 log units) above what was measured, within the range that was stated.
By their numbers in this assay, from the lowest: compounds 3, 2 and 1 (each within the scatter of the next).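

On the sulfonamide nitrogen, 2,6-dimethoxypyrimidin-4-yl cannot be told apart in this assay from 4,6-dimethylpyrimidin-2-yl (a 1.0-fold lower number from compound 2 to compound 3 (0.01 log units; within the scatter)) or from acetyl (a 1.1-fold lower number from compound 1 to compound 3 (0.05 log units; within the scatter)). All three groups now lie within the scatter of one another, so this place shows no separable response to any change among them, including a second pyrimidine attached differently and carrying methoxy groups. No supporting measurement accounts for this result.

Still open, from the compounds shown here alone, is whether a carboxylic acid or an amine on the pyrimidine, or a longer chain in place of it, would move the number beyond the scatter. The compounds shown also leave open whether changes elsewhere on the shared core would do so.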